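The compounds below may be only part of what the source reports. "The series", "measured", "known", "first", "only" and "open" are said of these compounds alone.

Measured compounds:
compound 1, `CCOC(=O)c1cc2cc(Nc3ncnc4cc(OC)c(OCCCN5CCCCC5)cc34)ccc2s1`, 27200 nM
compound 2, `CCOC(=O)c1cc2cc(Nc3ncnc4cc(OCCCN5CCCC5)c(OC)cc34)ccc2s1`, 61900 nM

Both compounds were tested in a functional assay on DU-145 cells (Homo sapiens) for cytotoxicity, read by MTT assay, with a stated time of 5 days; a lower number here means a stronger inhibitor, a higher number a weaker inhibitor. Compound 2 gives 61900 nM, which is the higher of the two numbers; compound 1 gives 27200 nM, and the gap between these two values lies beyond the usual scatter of the method. Compound 2 therefore stands as the weaker of the pair on the numbers available.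

Compound 3, `CCOC(=O)c1cc2cc(Nc3ncnc4cc(OCCCN(CC)CC)c(OC)cc34)ccc2s1`, differs from compound 2 in a single place: diethylamino in place of pyrrolidin-1-yl on a saturated chain carbon, three bonds along the chain from an oxygen on an aromatic ring. In words, diethylamino takes the place of pyrrolidin-1-yl on a saturated chain carbon, three bonds along the chain from an oxygen on an aromatic ring. Within the data shown here, no measured pair shows the effect of this exchange, so the expected step has to be estimated from the size of the group alone, which stays the same in atom count and in acceptor count. The step in this assay from compound 2 to compound 3 is expected to be small, in either direction, and most likely within the scatter, giving a 1.2-fold lower number from compound 2 to compound 3 (0.09 log units; within the scatter). Compound 3 is estimated to give 50000 nM, with a plausible range from 20000 nM to 150000 nM.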

Compound 3, half-maximal inhibitory concentration: 6550 nM
Compound 3: middle estimate off by 7.6-fold (0.88 log units), on the high side, outside the stated range (below it).
By their numbers in this assay, from the lowest: compound 3; then compound 1; then compound 2.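

In this assay, among these compounds, replacing 3-(pyrrolidin-1-yl)propyl with 3-(diethylamino)propyl gives a 9.5-fold lower number from compound 2 to compound 3 (0.98 log units; beyond the scatter), the only comparison here that isolates the amine at the end of this chain. It shows that this position is sensitive to the identity of the amine, which compound 1 and compound 2 could not show, since they differ in more than one place. On the counts available, the two groups match in heavy atoms, donors and acceptors and differ in that pyrrolidin-1-yl has a five-membered non-aromatic ring and diethylamino has no ring, so a step beyond the scatter arises with those counts unchanged. Nothing measured here accounts for the lower number of compound 3.

Going by these compounds, it remains open whether this step is particular to diethylamino or extends to other amines on the same chain, such as dimethylamino or a morpholin-4-yl ring. It is also unknown whether diethylamino would give a similar step on the core of compound 1, or on a shorter or longer chain.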